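Salicylanilide series: dibromination on a benzothiazolylthio anilide

The compounds below may be only part of what the source reports. "The series", "measured", "known", "first", "only" and "open" are said of these compounds alone.

Compound 1 `O=C(Nc1ccccc1)c1cc(Br)ccc1O`: in an assay on isolated protein for inhibition of thiosulfate sulfurtransferase (Homo sapiens), with a stated time of 60 min, in the absence of a further agent (a lower number here means a stronger inhibitor, a higher number a weaker inhibitor), compound 1 gives > 100000 nM, which is a limit of the assay.
Compound 3 `O=C(Nc1ccccc1)c1cc(Br)cc(Br)c1O`: compound 3 gives > 100000 nM, a limit.
Compound 2 `O=C(Nc1ccc(Sc2nc3ccccc3s2)c(Cl)c1)c1cccc(Br)c1O`: compound 2 gives > 100000 nM, a limit.

Compound 2 therefore stands at the assay limit, as do the other two measured compounds; all three values sit at the limit of > 100000 nM in this assay, at which 3 of the 3 values shown sit, so no order among them can be read. Compound 4 `O=C(Nc1ccc(Sc2nc3ccccc3s2)c(Cl)c1)c1cc(Br)cc(Br)c1O` differs from compound 2 by bromo in place of hydrogen on an aromatic carbon. Going by the values given here, the one measured step of the same kind, a step that the two limits leave unreadable from compound 1 to compound 3, is unreadable because both ends are limits, so it gives no size. Among the compounds with values here, no other measured pair bears on the change. Nothing in the data suggests that the added bromo moves the value into the readable range, so the step that the limit leaves unreadable from compound 2 to compound 4 is expected to be none beyond the scatter, with compound 4 most likely reported again as a limit. Compound 4 is estimated at 150000 nM, between 50000 nM and 500000 nM.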

Compound 4, half-maximal inhibitory concentration: > 100000 nM
Compound 4: no number, only a limit (the forecaster's own chance of this, stated with the estimate: 85%); the middle value lies beyond the limit too.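

No step can be read from compound 2 to compound 4 in this assay, as both values are limits: the limit of > 100000 nM in this assay, at which 4 of the 4 values shown sit.

The compounds shown leave open whether going from 3-bromo-2-hydroxyphenyl to 3,5-dibromo-2-hydroxyphenyl changes the read-out at all, with no readable number yet anchoring the series.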